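A few compounds are considered here, and "the series" means these few. Any claim that something is new, unique, unknown or untested is made for them only; others in the source may bear on it.

Compound 1 `C=C1CC[C@H]2[C@@](C)(CCC(=O)N[C@@]2(C)COC(=O)c2cccnc2)[C@@H]1/C=C/C1=CCOC1=O` gives > 50000 nM (a limit)
Compound 2 `C=C1CC[C@H]2[C@@](C)(CCC(=O)N[C@@]2(C)COC(=O)[C@@H]2CCCN2)[C@@H]1/C=C/C1=CCOC1=O` gives > 50000 nM (a limit)
Compound 3 `C=C1CC[C@H]2[C@@](C)(CC[C@@H](OC(=O)c3ccccc3)[C@@]2(C)NC=O)[C@@H]1/C=C/C1=CCOC1=O` gives 50000 nM (a number)

For the measured compounds named here, in a functional assay on RAW264.7 cells (Mus musculus) for inhibition, read by Griess assay, with stated times of 3 h and 24 h (a higher number here means a weaker inhibitor, a lower number a stronger inhibitor), compound 3 gives 50000 nM as the only true number of the three. The change to compound 4 `C=C1CC[C@H]2[C@@](C)(CC[C@@H](OC(=O)[C@H]3CCCN3)[C@@]2(C)NC=O)[C@@H]1/C=C/C1=CCOC1=O` is pyrrolidin-2-yl in place of phenyl on a carbonyl carbon. Going by the values given here, the only measured step with the same entering group is a step that the two limits leave unreadable from compound 1 to compound 2, which starts from pyridin-3-yl rather than phenyl and offers no size. Compound 2, which carries that pyrrolidin-2-yl, reads > 50000 nM as a limit and not a number. Beyond that, the series offers only the limit of > 50000 nM in this assay, at which 2 of the 3 values shown sit, as a guide. No step beyond the scatter is therefore expected in this assay, in either direction. The estimated step, a 1.3-fold lower number from compound 3 to compound 4 (0.10 log units; within the scatter), is expected to stay within the scatter. For compound 4 the expected value is 40000 nM, with an estimated range of 12000 nM to 80000 nM, though the assay may well report only a limit.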

Compound 4, half-maximal inhibitory concentration: > 50000 nM
Compound 4 ended at the assay's limit; the forecaster's own chance of this, stated with the estimate: 60%; at least 1.2-fold (0.09 log units) between middle value and limit.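

In this assay, the change from phenyl to pyrrolidin-2-yl on this carbonyl carbon gives a number no lower from compound 3 to compound 4 (the limit leaves the size open), so unlike the earlier step with the same entering group, this one has a readable direction. Compound 4 gives > 50000 nM, which is a limit and not a number. Swapping the aromatic ring of carbon only for this non-aromatic ring with its hydrogen-bond donor therefore brought no lower number at this position, and the limit now holds for most of the series: the limit of > 50000 nM in this assay, at which 3 of the 4 values shown sit.

How far compound 4 lies from compound 3 stays open, and the compounds shown give no number lower than that of compound 3. From the compounds shown here alone, whether an amine on a longer chain or a carboxylic acid on this carbonyl carbon would give a readable number also remains open.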